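Thiourea chain swap on the pyridazinone side chain

A few compounds are considered here, and "the series" means these few. Any claim that something is new, unique, unknown or untested is made for them only; others in the source may bear on it.

Compound 1 `C/N=C(/NC#N)NCCCCn1nc(N(C)C)ccc1=O` gives 26.3%.
Compound 2 `CC/N=C(\S)NCCCCCCn1nc(-c2ccccc2)ccc1=O` gives -5.6%.
Compound 3 `O=c1ccc(-c2ccccc2)nn1CCCC/N=C(\S)Nc1cccc(F)c1` gives 30.4%.

These three values come from a functional assay on the whole organism with Rattus norvegicus as the target, at a dose of 100 mg/kg; a lower number here means less inhibition, a higher number more inhibition at the dose given (going by the name of the read-out). Compound 2 stands lowest of the three numbers; compound 1 lies beyond the scatter above it, and compound 3 lies further still above it, also beyond the scatter. Compound 4 `C=CCNC(=S)NCCCCn1nc(-c2ccccc2)ccc1=O` is not yet measured. It differs from compound 2 by a group of 7 heavy atoms (4 carbon, 2 nitrogen, 1 sulfur; no ring) in place of a group of 8 heavy atoms (5 carbon, 2 nitrogen, 1 sulfur; no ring), on a saturated chain carbon, four bonds along the chain from an aromatic nitrogen. Among the measured compounds shown here, no measured pair of compounds shows such a step, so its size is open. The account expects compound 4 to move toward the range of compound 1 and compound 3, giving an estimated rise of a number 25.6 percentage points higher from compound 2 to compound 4 (beyond the scatter) in this assay. Compound 4 is therefore estimated at 20%, with a range from -10% to 45%.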

Compound 4, a percentage reported as inhibition, in the whole organism at one dose (the size of the read-out at that dose, not a potency): 27.1%
Compound 4: middle estimate off by 7.1 percentage points, on the low side, and the stated range covers the measured number.
By their numbers in this assay, from the lowest: compound 2; then compounds 1, 4 and 3 (each within the scatter of the next).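

In this assay, the exchange on a saturated chain carbon, four bonds along the chain from an aromatic nitrogen, gives a number 32.7 percentage points higher from compound 2 to compound 4 (beyond the scatter) and is the first single-place step shown. This place therefore responds strongly to the exchange, even though both groups count the same hydrogen-bond donors and acceptors and neither has a ring. Among the compounds shown here, the single step cannot assign the rise to any one part of the exchanged group, and how a benzyl group or a carboxylic acid would fare at this place stays open. No measurement shown here accounts for the step.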